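The compounds below may be only part of what the source reports. "The series", "measured", "known", "first", "only" and "open" are said of these compounds alone.

Compound 3 `CCNC(=O)N1CC1C#N` sits second highest among the three numbers recorded in a functional assay on A-375 cells (Homo sapiens) for inhibition; a lower number here means a stronger inhibitor, a higher number a weaker inhibitor; in that assay compound 3 gives 36000 nM. Its nearest neighbour is compound 1 `CCCCNC(=O)N1CC1C#N`, which in this assay gives 15000 nM, while the furthest is compound 2 `CC(C)(C)NC(=O)N1CC1C#N`, which gives 418000 nM. The unmeasured compound 4 `CNC(=O)N1CC1C#N` differs from compound 3 in one place: hydrogen in place of methyl on a saturated chain carbon bound to an amide-type nitrogen, that is, ethyl to methyl, or ethylamino to methylamino.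

Of the measured steps, the one that most resembles this change is the chain shortening a 2.4-fold higher number from compound 1 to compound 3 (0.38 log units; beyond the scatter), a modest step that weakened inhibition. The two steps involving the branched group, a 28-fold higher number from compound 1 to compound 2 (1.45 log units; beyond the scatter) and a 12-fold lower number from compound 2 to compound 3 (1.06 log units; beyond the scatter), were large, but both concern a tert-butyl on the amide-type nitrogen rather than a shortening of a straight chain, so they bear only indirectly on the present step. Taking the straight-chain step as the guide, a further shortening by one carbon is expected to give a modest weakening, a 1.9-fold higher number from compound 3 to compound 4 (0.29 log units; within the scatter), in this assay. Compound 4 is therefore estimated at 70000 nM, with a range from 30000 nM to 160000 nM.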

Compound 4, half-maximal inhibitory concentration: 17000 nM
Compound 4: middle estimate off by 4.1-fold (0.61 log units), on the high side; measured number below the stated range.
By their numbers in this assay, from the lowest: compounds 1 and 4 (each within the scatter of the next); then compound 3; then compound 2.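

In this assay, cutting the ethyl group back to methyl did not extend the trend seen on shortening butyl to ethyl: the number fell (a 2.1-fold lower number from compound 3 to compound 4 (0.33 log units; beyond the scatter)) where the earlier shortening had raised it (a 2.4-fold higher number from compound 1 to compound 3 (0.38 log units; beyond the scatter)), so compound 3 now stands highest of the three straight-chain compounds rather than at the end of a series. The methyl and butyl compounds cannot be told apart (a 1.1-fold higher number from compound 1 to compound 4 (0.05 log units; within the scatter)), so among these compounds the length of the straight chain on the amide-type nitrogen does not set the order in a single direction. The tert-butyl compound stays far from even the shortest chain (a 25-fold lower number from compound 2 to compound 4 (1.39 log units; beyond the scatter)), which shows its large gap against methyl as well as against ethyl and butyl. Nothing at hand offers an explanation for this turn in the series.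

The compounds shown leave open whether a propyl chain would fall with ethyl or with butyl, and whether the rise at ethyl is more than a local feature of these few chains. They also leave open how isopropyl or cyclopropyl, a longer chain such as hexyl, or a carboxylic acid at the end of the chain would read here.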